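A few compounds are considered here, and "the series" means these few. Any claim that something is new, unique, unknown or untested is made for them only; others in the source may bear on it.

Three compounds of the series, compound 1 `CC(C)CSc1nc(N)nc2c1ncn2/C=C1/CC1(CO)CO`, compound 2 `Nc1nc(OCc2ccccc2)c2ncn(/C=C3/CC3(CO)CO)c2n1` and compound 3 `Nc1nc(NC2CCCCC2)c2ncn(/C=C3/CC3(CO)CO)c2n1`, have been run in an ADME assay on Akata cells (Homo sapiens) for cytotoxicity, with a stated time of 7 days; on this read-out lower numbers stand for higher toxicity in this test and higher numbers for lower toxicity in this test. In this assay compound 1 gives only a limit, > 20000 nM. Compound 2 likewise reaches only a limit, > 20000 nM. Compound 3 also stands at a limit, > 24000 nM. Within the data shown here, with every value a limit, the steps a step that the two limits leave unreadable from compound 1 to compound 2, a step that the two limits leave unreadable from compound 1 to compound 3 and a step that the two limits leave unreadable from compound 2 to compound 3 cannot be read, so no measured step bears on the change to compound 4 `CCCCOc1nc(N)nc2c1ncn2/C=C1/CC1(CO)CO`, which is butoxy in place of cyclohexylamino on an aromatic carbon. Given that compound 3 sits at a limit > 24000 nM, compound 4 is expected to reach only a limit too, the expected step being a step that the limit leaves unreadable from compound 3 to compound 4. Compound 4 is estimated at 30000 nM, within 10000 nM to 100000 nM.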

Compound 4, half-maximal cytotoxic concentration: > 20000 nM
Compound 4: no number, only a limit; the forecaster's own chance of this, stated with the estimate: 80%; the middle value does not contradict the limit.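

In this assay compound 4 stands only at a limit, so its steps from compound 1, compound 2 and compound 3 cannot be read. The compounds shown leave open whether any of these groups on the shared core changes the half-maximal cytotoxic concentration.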